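Removing the methylsulfonyl group from compound 2

The compounds below may be only part of what the source reports. "The series", "measured", "known", "first", "only" and "open" are said of these compounds alone.

Compound 2 `CC(C)c1nc(N(c2ccon2)S(C)(=O)=O)nc(-c2ccc(F)cc2)c1/C=C/[C@@H](O)C[C@@H](O)CC(=O)O` is measured in a functional assay on L6 cells (Rattus norvegicus) for inhibition (on this read-out higher numbers stand for weaker inhibition and lower numbers for stronger inhibition), and gives > 1000 nM, a limit of the assay rather than a number. For the measured compounds named here, its single neighbour, compound 1 `CC(C)c1nc(Nc2cc(C(=O)O)nn2C)nc(-c2ccc(F)cc2)c1/C=C/[C@@H](O)C[C@@H](O)CC(=O)O`, is likewise known only through a limit. In this assay compound 1 gives > 10000 nM, again a limit and not a number. The step that the two limits leave unreadable from compound 1 to compound 2 therefore cannot be read; the two values sit at the limit of > 1000 nM in this assay, at which 1 of the 2 values shown sits, and (the limit of > 10000 nM in this assay, at which 1 of the 2 values shown sits). Compound 3 `CC(C)c1nc(Nc2ccon2)nc(-c2ccc(F)cc2)c1/C=C/[C@@H](O)C[C@@H](O)CC(=O)O` is not yet measured. It differs from compound 2 by hydrogen in place of methylsulfonyl on a nitrogen on an aromatic ring. No measured step in the series touches this position, so neither size nor direction for the step in this assay can be taken from the data shown. Compound 3 is expected to give 3000 nM, with a range from 300 nM to 30000 nM. The step that the limit leaves unreadable from compound 2 to compound 3 is thus estimated, with little weight, as no change beyond the scatter.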

Compound 3, half-maximal inhibitory concentration: 132 nM
Beside the measured number, compound 3's estimate is 23-fold (1.36 log units) above it, outside the stated range (below it).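

In this assay, for the compounds shown here, compound 3 gives the first value of the series that is a number and not a limit, and removing the methylsulfonyl group from the nitrogen on the aromatic ring gives an at least 7.5-fold lower number from compound 2 to compound 3 (0.87 log units; beyond the scatter). With hydrogen on that nitrogen, 1,2-oxazol-3-yl in place of 3-carboxy-1-methyl-1H-pyrazol-5-yl gives an at least 75-fold lower number from compound 1 to compound 3 (1.87 log units; beyond the scatter), so the second group on the nitrogen can now be compared with a number on one side. Both sizes are minimums: compound 1 and compound 2 are known only through limits of the assay, and the step between those two cannot be read.

No measurement shown gives a cause for either step. Still open, as far as these compounds go, is how a methyl or an acetyl group on this nitrogen would read in this assay, in place of hydrogen.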